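Pyridin-2-yl for 4-bromophenyl: cytotoxicity limits in the series

A few compounds are considered here, and "the series" means these few. Any claim that something is new, unique, unknown or untested is made for them only; others in the source may bear on it.

In an ADME assay on MT4 cells (Homo sapiens) for cytotoxicity, read by XTT assay, with a stated time of 5 days (on this read-out lower numbers stand for higher toxicity in this test and higher numbers for lower toxicity in this test), compound 1 `CNC(=O)[C@@H](NC(=O)[C@@](O)(CCN(Cc1ccc(Br)cc1)NC(=O)[C@@H](NC(=O)OC)C(C)(C)C)Cc1ccccc1)C(C)(C)C` gives > 10000 nM as a limit, not a number. Compound 2 `CNC(=O)[C@@H](NC(=O)[C@@](O)(CCN(Cc1ccc(Br)cc1)NC(=O)[C@@H](NC(=O)OC)C(C)(C)C)Cc1ccccc1)C(C)C` gives > 10000 nM as a limit. Compound 3 `COCCNC(=O)[C@@H](NC(=O)[C@@](O)(CCN(Cc1ccc(Br)cc1)NC(=O)[C@@H](NC(=O)OC)C(C)(C)C)Cc1ccccc1)C(C)C` gives > 10000 nM as a limit. Compound 1 thus stands with the other two at the limit of > 10000 nM in this assay, at which 3 of the 3 values shown sit, and no rank can be read. Compound 4 `CNC(=O)[C@@H](NC(=O)[C@@](O)(CCN(Cc1ccccn1)NC(=O)[C@@H](NC(=O)OC)C(C)(C)C)Cc1ccccc1)C(C)(C)C` differs from compound 1 by pyridin-2-yl in place of 4-bromophenyl on a saturated chain carbon bound to an amine nitrogen with pyridin-2-yl in place of 4-bromophenyl. The measured steps a step that the two limits leave unreadable from compound 1 to compound 2 and a step that the two limits leave unreadable from compound 1 to compound 3 and a step that the two limits leave unreadable from compound 2 to compound 3 all keep 4-bromophenyl and have no readable size. The expected change in this assay is therefore a step that the limit leaves unreadable from compound 1 to compound 4 and none beyond the scatter, in no clear direction. Compound 4 is estimated at 15000 nM with 6000 nM to 40000 nM as its expected range.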

Compound 4, half-maximal cytotoxic concentration: > 10000 nM
Compound 4 ended at the assay's limit (the forecaster's own chance of this, stated with the estimate: 85%); the middle value lies beyond the limit too.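

In this assay, no new step can be read between compound 1 and compound 4, as both values are limits, not numbers: the limit of > 10000 nM in this assay, at which 4 of the 4 values shown sit.

Whether pyridin-2-yl in place of 4-bromophenyl shifts cytotoxicity at all stays open, as does any rank among the compounds shown.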